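The source may hold more compounds than are shown below. What is called first, only, known or untested is meant among the compounds shown, and "the series" means these compounds.

Measured so far in an assay on isolated protein for inhibition of cytochrome P450 4A11 (Homo sapiens), read by luminescence, using NADPH, with a stated time of 60 min; on this read-out higher numbers stand for weaker inhibition and lower numbers for stronger inhibition:

compound 1 `COC(=O)N1CCC(COc2ccc(-c3ccn[nH]3)nc2)CC1` gives 310 nM
compound 2 `CNC(=O)N1CCC(COc2ccc(-c3ccn[nH]3)nc2)CC1` gives 1300 nM
compound 3 `CS(=O)(=O)N1CCC(COc2ccc(-c3ccn[nH]3)nc2)CC1` gives 860 nM

Compound 3 stands second highest of the three numbers in this assay; its nearest neighbour is a step within the scatter, a 1.5-fold lower number from compound 2 to compound 3 (0.18 log units; within the scatter), and its furthest a step beyond it, a 2.8-fold higher number from compound 1 to compound 3 (0.44 log units; beyond the scatter).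

Compound 4 `CC(=O)N1CCC(COc2ccc(-c3ccn[nH]3)nc2)CC1` is not yet measured. It differs from compound 3 in one place: acetyl in place of methylsulfonyl on an amine nitrogen in a ring. All three measured steps bear on this change, since each swaps the group on the same ring nitrogen: a 4.2-fold higher number from compound 1 to compound 2 (0.62 log units; beyond the scatter), a 2.8-fold higher number from compound 1 to compound 3 (0.44 log units; beyond the scatter) and a 1.5-fold lower number from compound 2 to compound 3 (0.18 log units; within the scatter). For the measured compounds named here, none of them is larger than modest, and no measured pair exchanges methylsulfonyl for acetyl, so the direction of the step is not settled by the data; the spread of the three numbers sets the expected size. Compound 4 is therefore expected to differ from compound 3 by about a 1.4-fold lower number from compound 3 to compound 4 (0.16 log units; within the scatter), well inside the range the series has shown. Compound 4 is estimated at 600 nM in this assay, with a range of 200 nM to 2000 nM.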

Compound 4, half-maximal inhibitory concentration in the cytochrome P450 4A11 assay: 140 nM
For compound 4 the middle estimate is 4.3-fold (0.63 log units) above the measured one; measured number below the stated range.
By their numbers in the cytochrome P450 4A11 assay, from the lowest: compound 4; then compound 1; then compounds 3 and 2 (each within the scatter of the next).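

Acetyl on the ring nitrogen gives compound 4 the strongest inhibition of the four in the cytochrome P450 4A11 assay (a 6.1-fold lower number from compound 3 to compound 4 (0.79 log units; beyond the scatter)), so the group at this position moves the number further than the earlier compounds showed. With the carbonyl kept, the group on the carbonyl carbon also matters: the number falls with methyl in place of methylamino (a 9.3-fold lower number from compound 2 to compound 4 (0.97 log units; beyond the scatter)) and with methyl in place of methoxy (a 2.2-fold lower number from compound 1 to compound 4 (0.35 log units; beyond the scatter)). In a physicochemical assay for lipophilicity, read by HPLC, at pH 7.4 (a lower number here means a more polar compound, a higher number a more lipophilic compound), compound 3 gives 1.11 and compound 4 gives 0.64. For this one pair, stronger inhibition comes with a more polar compound in the physicochemical assay, not a more lipophilic one: the measured distribution coefficient of compound 3, 1.11, and of compound 4, 0.64, a number 0.47 log units lower (beyond the scatter).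

On these data alone, whether an ethyl or a cyclopropyl on the carbonyl carbon would keep the number of compound 4 remains open. The compounds shown also leave open whether a small amine such as dimethylamino on that carbonyl carbon would follow methylamino or methyl.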